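Growing the acyl group of compound 2

The compounds below may be only part of what the source reports. "The series", "measured", "known", "first", "only" and "open" are said of these compounds alone.

Compound 1 `CC(=O)N(C)c1ccc2[nH]c(-c3n[nH]c4ccccc34)cc2n1` and compound 2 `CCC(=O)N(C)c1ccc2[nH]c(-c3n[nH]c4ccccc34)cc2n1` share a core and differ only in the acyl group on the amide-type nitrogen. In a functional assay on A549 cells (Homo sapiens) for antiproliferative activity, read by MTT assay, with a stated time of 72 h (a higher number here means a weaker inhibitor, a lower number a stronger inhibitor), compound 1 gives only a limit, > 50000 nM. In this assay, for the measured compounds named here, compound 2 gives 15700 nM, the only number in the set. The other value, that of compound 1, is a limit. The step of an at least 3.1-fold lower number from compound 1 to compound 2 (0.50 log units; beyond the scatter) shows that a methyl in place of hydrogen carried the compound from the limit of > 50000 nM in this assay, at which 1 of the 2 values shown sits, to a measurable number.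

Compound 3 `CN(C(=O)C(C)(C)C)c1ccc2[nH]c(-c3n[nH]c4ccccc34)cc2n1` continues in the same direction: tert-butyl in place of ethyl on a carbonyl carbon. Only the step from compound 1 to compound 2 bears on it, and that step was at least modest; how much of it would carry over to a branched tert-butyl group is not shown. A further lowering in this assay is therefore expected, of a size that could be within the scatter or somewhat beyond it, as a 2.6-fold lower number from compound 2 to compound 3 (0.42 log units; beyond the scatter). Compound 3 is estimated at 6000 nM in this assay, with a range from 1500 nM to 25000 nM.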

Compound 3, half-maximal inhibitory concentration: 24400 nM
Estimate against measurement, compound 3: 4.1-fold (0.61 log units) below; the measured number falls inside the stated range.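

The change from ethyl to tert-butyl on the carbonyl carbon moves nothing that can be read in this assay, with a 1.6-fold higher number from compound 2 to compound 3 (0.19 log units; within the scatter), so compound 2 and compound 3 cannot be told apart and the lowering that came with the first added methyl did not continue as the acyl group grew and branched. The position still tolerates the branched group without a return to the limit, since the result reads an at least 2.0-fold lower number from compound 1 to compound 3 (0.31 log units; beyond the scatter), and tert-butyl and ethyl on this carbonyl carbon thus both give a measurable number where methyl does not. Compound 1 supplies only a limit, so this comparison has one open end: the limit of > 50000 nM in this assay, at which 1 of the 3 values shown sits.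

The compounds shown leave open whether a longer straight chain on the carbonyl carbon, or an acyl group carrying an amine or a carboxylic acid, would lower the number beyond the scatter. They also leave open what the methyl on the amide-type nitrogen contributes, as all of them carry it and none has a hydrogen or an ethyl group there.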